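Stretching the sulfur-bearing group on compound 3's aromatic ring

A few compounds are considered here, and "the series" means these few. Any claim that something is new, unique, unknown or untested is made for them only; others in the source may bear on it.

Of the compounds shown here, three sharing one core have been measured in an assay on CHO cells for displacement of a labelled ligand from prostaglandin D2 receptor 2 (Homo sapiens), read by scintillation counting; a higher number here means a weaker inhibitor, a lower number a stronger inhibitor. Compound 1 `CCCS(=O)(=O)c1cccc(C#Cc2cc(Cl)ccc2OCC(=O)O)c1` gives 9 nM. Compound 2 `CN(c1cccc(C#Cc2cc(Cl)ccc2OCC(=O)O)c1)S(C)(=O)=O` gives 122 nM. Compound 3 `C[S+]([O-])c1cccc(C#Cc2cc(Cl)ccc2OCC(=O)O)c1` gives 3.2 nM, the lowest of the three numbers; compound 1 lies nearest, and compound 2 furthest, as the steps show: a 2.8-fold lower number from compound 1 to compound 3 (0.45 log units; beyond the scatter) and a 38-fold lower number from compound 2 to compound 3 (1.58 log units; beyond the scatter). Compound 4 `CS(=O)(=O)Cc1cccc(C#Cc2cc(Cl)ccc2OCC(=O)O)c1` is the next compound, unmeasured so far. It differs from compound 3 only in one place: a group of 5 heavy atoms (2 carbon, 2 oxygen, 1 sulfur; no ring) in place of a group of 3 heavy atoms (1 carbon, 1 oxygen, 1 sulfur; no ring), on an aromatic carbon. Within the data shown here, the steps that bear on this change both run toward compound 3 from a larger group on the same aromatic carbon, and in each case the number fell, modestly in one case and strongly in the other. Moving back to a larger group in compound 4 is therefore expected to raise the number, but since the group entering here is a sulfonyl-bearing chain closer in kind to that of compound 1 than to that of compound 2, the expected step of a 2.5-fold higher number from compound 3 to compound 4 (0.40 log units; beyond the scatter) is modest rather than large. In this assay compound 4 is expected to give about 8 nM, within a range from 3 nM to 25 nM.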

Compound 4, inhibition constant: 48 nM
The estimate for compound 4 lay 6.0-fold (0.78 log units) below the measured number, outside the stated range (above it).
By their numbers in this assay, from the lowest: compound 3; then compound 1; then compound 4; then compound 2.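

In this assay, the swap to (methylsulfonyl)methyl gives a 15-fold higher number from compound 3 to compound 4 (1.18 log units; beyond the scatter), so this aromatic carbon tolerates this larger sulfur-bearing group much less well than the comparison with compound 1 alone suggested. Carrying a sulfonyl group is clearly not enough, as the comparison with the propylsulfonyl group gives a 5.3-fold higher number from compound 1 to compound 4 (0.73 log units; beyond the scatter), while the comparison with the methyl(methylsulfonyl)amino group gives a 2.5-fold lower number from compound 2 to compound 4 (0.41 log units; beyond the scatter). Across these four compounds, the two with sulfur attached directly to the aromatic carbon, compound 1 and compound 3, give lower numbers than the two with a carbon or nitrogen link, compound 2 and compound 4.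

No measurement here explains why the link matters so much. On these data alone, it remains open how a methylsulfonyl group attached directly to the ring, or a sulfonyl group linked through an oxygen atom, would behave at this position.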